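Extending the chain from compound 2 to compound 4

The source may report more compounds than this note shows. Statements on the series, on what has been measured and on what is new or still open speak of the compounds shown alone.

Among the compounds with values here, in a functional assay on L6 cells (Rattus norvegicus) for cytotoxicity (a higher number here means a weaker inhibitor, a lower number a stronger inhibitor), compound 1 (`O=C(OCCOCn1ccc(=O)[nH]c1=O)c1ccccc1`) gives 202000 nM as the only number so far. Compound 2 (`O=c1ccn(CCCO)c(=O)[nH]1`) has no single number: compound 2 reads "not determined" (no result reported) and no result was reported for it. Compound 3 (`O=C(OCCCCn1ccc(=O)[nH]c1=O)c1ccccc1`) likewise has no result: compound 3 reads "not determined" (no result reported) in the same way. Compound 4 (`O=c1ccn(CCCCCO)c(=O)[nH]1`) is still to be measured. The structural change is 2-hydroxyethyl in place of hydroxy on a saturated chain carbon, three bonds along the chain from an aromatic nitrogen and amounts to 2-hydroxyethyl in place of hydroxy on a saturated chain carbon, three bonds along the chain from an aromatic nitrogen. Within the data shown here, no measured step is available as a guide. The expected step in this assay is therefore none beyond the scatter, with compound 1 at 202000 nM as the only reference level. Compound 4 is estimated at 200000 nM with 80000 nM to 450000 nM as its expected range.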

Compound 4, half-maximal inhibitory concentration: > 454000 nM
Compound 4 gave a limit, no number (the forecaster's own chance of this, stated with the estimate: 35%); middle value at least 2.2-fold (0.35 log units) from the limit.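

Compound 4 gives > 454000 nM in this assay, which is a limit and not a number. Within the data shown here, compound 2 has no single number, so no step from compound 2 to compound 4 can be read. As far as these compounds go, whether 2-hydroxyethyl in place of hydroxy shifts cytotoxicity stays open.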